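Shortening the Tail of a Vanillyl Amide

The source may report more compounds than this note shows. Statements on the series, on what has been measured and on what is new or still open speak of the compounds shown alone.

Compound 1 `COc1cc(CNC(=O)/C=C(\C)CCC[C@H](C)CCC[C@H](C)CCCC(C)C)ccc1O` gives 2 nM in a functional assay on HEK293 cells with transient receptor potential cation channel subfamily V member 1 (Homo sapiens) as the target; on this read-out lower numbers stand for an effect already at smaller amounts and higher numbers for an effect only at larger amounts of compound.
Compound 2 `CCCCCCCCC#CCCCCCCCC(=O)NCc1ccc(O)c(OC)c1` gives 12.6 nM in this assay.
Compound 3 `CCCCCC/C=C/C#CCCCCCCCC(=O)NCc1ccc(O)c(OC)c1` gives 1.26 nM in this assay.

Compound 3 and compound 1 sit within the scatter of each other, while the step of a 10-fold lower number from compound 2 to compound 3 (1.00 log units; beyond the scatter) sets compound 2 clearly apart. Compound 4 `C=CCCCCCCCCC(=O)NCc1ccc(O)c(OC)c1` arises from compound 3 by a group of 3 heavy atoms (3 carbon; no ring) in place of a group of 10 heavy atoms (10 carbon; no ring), on a saturated chain carbon, seven bonds along the chain from a carbonyl carbon. Among the compounds with values here, no measured step covers such a cut of the chain: the only step known swaps groups of equal size at the triple bond, so it bears little on this change. With so much of the tail gone, the expected step of a 48-fold higher number from compound 3 to compound 4 (1.68 log units; beyond the scatter) is toward a higher number in this assay. Compound 4 is therefore estimated at 60 nM, within 8 nM to 500 nM.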

Compound 4, half-maximal effective concentration: 2 nM
Beside the measured number, compound 4's estimate is 30-fold (1.48 log units) above it, and the stated range ends above it.
By their numbers in this assay, from the lowest: compounds 3, 1 and 4 (each within the scatter of the next); then compound 2.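

In this assay, the cut at this saturated chain carbon gives a 1.6-fold higher number from compound 3 to compound 4 (0.20 log units; within the scatter), so allyl matches the group of 10 heavy atoms it replaces, and this much of the tail can go without a change beyond the scatter. The group here still matters, since allyl in place of dec-1-yn-1-yl gives a 6.3-fold lower number from compound 2 to compound 4 (0.80 log units; beyond the scatter), and a smaller group thus goes with the lower number in this pair. Nothing available explains either result.

Still open, as far as these compounds go, is how far the chain can shrink, and whether a propyl group would match allyl here. From the compounds shown here alone, a carboxylic acid at the chain end is equally open.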